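From Ethyl to Isopropyl on a Shared Core

This account rests on a few compounds, and the source may have more. Where it says the series, first, only, none or still open, it means among the compounds named here.

Compound 1 `Cc1ccc(-c2nc(N)c3cc(Cc4ccccc4)sc3n2)o1`: 298 nM
Compound 2 `CCc1ccc(-c2nc(N)c3cc(Cc4ccccc4)sc3n2)o1`: 223 nM

Of the compounds shown here, two have been measured in a functional assay on CHO-K1 cells for antagonist activity at adenosine receptor A1 (Homo sapiens), read by a beta-galactosidase reporter and cAMP accumulation, with stated times of 15 min and 6 h; a lower number here means a stronger inhibitor, a higher number a weaker inhibitor. Compound 1 gives 298 nM, and compound 2 gives 223 nM. Compound 2 has the lowest of the two numbers, but its nearest neighbour is compound 1, and the step of a 1.3-fold lower number from compound 1 to compound 2 (0.13 log units; within the scatter) is within the scatter, so the two cannot be told apart.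

Compound 3 `CC(C)c1ccc(-c2nc(N)c3cc(Cc4ccccc4)sc3n2)o1` differs from compound 2 by methyl in place of hydrogen on a saturated chain carbon bound to an aromatic carbon and a saturated chain carbon. Going by the values given here, the only measured step that bears on it is a 1.3-fold lower number from compound 1 to compound 2 (0.13 log units; within the scatter), the earlier growth of the same chain by one carbon, which produced no change beyond the scatter. On that basis the further lengthening to isopropyl is expected to leave this assay essentially unchanged, with a 1.1-fold lower number from compound 2 to compound 3 (0.05 log units; within the scatter) as the anticipated step. Compound 3 is therefore estimated at 200 nM, within a range of 100 nM to 450 nM.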

Compound 3, inhibition constant: 283 nM
Estimate against measurement, compound 3: 1.4-fold (0.15 log units) below; the range from low to high includes it.
By their numbers in this assay, from the lowest: compounds 2, 3 and 1 (each within the scatter of the next).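

In this assay, the branched isopropyl group cannot be told apart from the ethyl group it replaces (a 1.3-fold higher number from compound 2 to compound 3 (0.10 log units; within the scatter)), nor from the methyl group of compound 1 (a 1.1-fold lower number from compound 1 to compound 3 (0.02 log units; within the scatter)). Compounds 1 and 2 covered only a straight chain, so the new information is that branching on the saturated chain carbon bound to the aromatic carbon also gives no step beyond the scatter, and methyl, ethyl and isopropyl all read alike here. Nothing available offers any explanation for this flat result.

From the compounds shown here alone, what a longer chain, a cyclopropyl group, an amine or a carboxylic acid would do in this place remains open. The compounds shown also leave open whether the same flat reading would hold at other adenosine receptors.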